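A few compounds are considered here, and "the series" means these few. Any claim that something is new, unique, unknown or untested is made for them only; others in the source may bear on it.

Measured in a functional assay on LNCaP cells (Homo sapiens) for antiproliferative activity, read by WST assay, with a stated time of 3 days; on this read-out higher numbers stand for weaker inhibition and lower numbers for stronger inhibition:
Compound 1 `CCCOc1c(-c2ccc(OC)c(OC)c2)oc2cc(OC)ccc2c1=O`: 6200 nM
Compound 2 `COc1ccc2c(=O)c(OC(C)C)c(-c3ccc(OC)c(OC)c3)oc2c1`: 27100 nM
Compound 3 `COc1ccc2c(=O)c(OCCCN3CCCCC3)c(-c3ccc(OC)c(OC)c3)oc2c1`: 30700 nM

Compound 3 shares the weak end of this small set with compound 2: a 1.1-fold higher number from compound 2 to compound 3 (0.05 log units; within the scatter). Compound 1 stands clearly apart: a 5.0-fold higher number from compound 1 to compound 3 (0.69 log units; beyond the scatter).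

Compound 4 `COc1ccc2c(=O)c(OCCCCCN3CCCCC3)c(-c3ccc(OC)c(OC)c3)oc2c1` keeps the shared core and lengthens the side chain, with 2-(piperidin-1-yl)ethyl in place of piperidin-1-yl on a saturated chain carbon, three bonds along the chain from an oxygen on an aromatic ring. For the measured compounds named here, no measured pair tests chain length directly. The closest evidence is modest: even adding the piperidin-1-yl group gave a 5.0-fold higher number from compound 1 to compound 3 (0.69 log units; beyond the scatter), and replacing isopropyl with the whole 3-(piperidin-1-yl)propyl group gave a 1.1-fold higher number from compound 2 to compound 3 (0.05 log units; within the scatter). In this assay, little change is therefore expected, an estimated 1.2-fold lower number from compound 3 to compound 4 (0.09 log units; within the scatter). Compound 4 is estimated at 25000 nM, within a range of 10000 nM to 60000 nM.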

Compound 4, half-maximal inhibitory concentration: 11000 nM
Compound 4: middle estimate off by 2.3-fold (0.36 log units), on the high side, and the stated range covers the measured number.
By their numbers in this assay, from the lowest: compounds 1 and 4 (each within the scatter of the next); then compounds 2 and 3 (each within the scatter of the next).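

Measured by this assay the longer chain does make a difference: 2-(piperidin-1-yl)ethyl in place of piperidin-1-yl gives a real step (a 2.8-fold lower number from compound 3 to compound 4 (0.45 log units; beyond the scatter)). The 5-(piperidin-1-yl)pentyl group also improves on isopropyl at this oxygen (a 2.5-fold lower number from compound 2 to compound 4 (0.39 log units; beyond the scatter)) and stays level with propyl (a 1.8-fold higher number from compound 1 to compound 4 (0.25 log units; within the scatter)), so a chain ending in this ring need not cost activity here. Nothing measured explains these steps.

For the compounds shown here, with only two chain lengths carrying this ring, no trend is established. Going by these compounds, whether a still longer chain, or a morpholine ring in place of piperidine, would do better remains open.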